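Compound 3 to compound 4: extending the dimethylamino group

This account rests on a few compounds, and the source may have more. Where it says the series, first, only, none or still open, it means among the compounds named here.

In a physicochemical assay for solubility, in phosphate buffer, at pH 6.5 (a lower number here means a less soluble compound, a higher number a more soluble compound), compound 3 `CN(C)Cc1ccc(NC(=O)Nc2cccnc2Oc2ccccc2C(C)(C)C)c(F)c1` stands highest at 160 ug/mL, ahead of compound 1 `CC(C)(C)c1ccccc1Oc1ncccc1NC(=O)Nc1ccc(C2(CO)CC2)cc1` at 5 ug/mL and compound 2 `CC(C)(C)c1ccccc1Oc1ncccc1NC(=O)Nc1ccc(-c2ccccc2CO)cc1F` at 2 ug/mL. Compound 4 `CN(C)Cc1cccc(-c2ccc(NC(=O)Nc3cccnc3Oc3ccccc3C(C)(C)C)c(F)c2)c1` carries 3-((dimethylamino)methyl)phenyl in place of (dimethylamino)methyl, on an aromatic carbon meta to a fluoro group and para to a large group: 3-((dimethylamino)methyl)phenyl in place of (dimethylamino)methyl on an aromatic carbon. Among the compounds with values here, one measured step bears on this: an 80-fold higher number from compound 2 to compound 3 (1.90 log units; beyond the scatter), a large step with (dimethylamino)methyl in place of 2-(hydroxymethyl)phenyl. Compound 4 holds a phenyl ring, as compound 2 does, and also keeps the (dimethylamino)methyl group, so part of that step is expected to be given back. Within the data shown here, no measured step isolates the ring alone. The expected step is a 6.4-fold lower number from compound 3 to compound 4 (0.81 log units; beyond the scatter), towards a lower number and beyond the scatter. For compound 4 the estimated value is 25 ug/mL, with an expected range of 5 ug/mL to 100 ug/mL.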

Compound 4, solubility: 17 ug/mL
Compound 4: middle estimate off by 1.5-fold (0.17 log units), on the high side; measured number inside the range.
By their numbers in this assay, from the lowest: compound 2; then compound 1; then compound 4; then compound 3.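

Placing 3-((dimethylamino)methyl)phenyl on this aromatic carbon in this assay gives a 9.4-fold lower number from compound 3 to compound 4 (0.97 log units; beyond the scatter) and, against the ring-bearing comparator, an 8.5-fold higher number from compound 2 to compound 4 (0.93 log units; beyond the scatter). The earlier step changed the ring and the (dimethylamino)methyl group together, whereas these two steps show that a phenyl ring here does not cancel the whole gain seen with that group. No measurement shown gives a reason for either step. Compounds 2 and 4 differ in both the group on the phenyl ring and its place, so neither effect can be read alone. A morpholine or a carboxylic acid on that ring remains an open comparison.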